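A few compounds are considered here, and "the series" means these few. Any claim that something is new, unique, unknown or untested is made for them only; others in the source may bear on it.

Working notes on the series. Of the compounds shown here, three sharing one core have been measured in a functional assay on B16-F10 cells (Mus musculus) for cytotoxicity (a lower number here means a stronger inhibitor, a higher number a weaker inhibitor), so far. Compound 1 `O=c1oc2ccccc2c2nc3c(ccc4cc[nH]c43)c(-c3ccc(C(F)(F)F)cc3)c12` carries 4-(trifluoromethyl)phenyl and gives 70700 nM in this test. Compound 2 `O=c1oc2ccccc2c2nc3c(ccc4cc[nH]c43)c(-c3cccnc3Cl)c12` carries 2-chloropyridin-3-yl and gives 70700 nM on the same read-out. Compound 3 `Cc1ccc(-c2c3ccc4cc[nH]c4c3nc3c2c(=O)oc2ccccc23)cc1` carries 4-methylphenyl and gives 70700 nM, which places it level with the other two.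

Among the measured compounds shown here, compound 4 `O=c1oc2ccccc2c2nc3c(ccc4cc[nH]c43)c(-c3ccc(F)cc3)c12` has no measurement yet. It differs from compound 3 by fluoro in place of methyl on an aromatic carbon, para to a large group. Cut one bond further out, this reads 4-methylphenyl to 4-fluorophenyl.

For the measured compounds named here, three measured steps bear on this change. The closest is no change at the digits printed from compound 1 to compound 3 (within the scatter), methyl in place of trifluoromethyl on an aromatic carbon. The other two, no change at the digits printed from compound 1 to compound 2 (within the scatter) and no change at the digits printed from compound 2 to compound 3 (within the scatter), exchange the whole group. All three lie within the scatter, so they offer no size or direction to carry over, and no step beyond the scatter is expected in this assay. The estimated step is a 1.0-fold lower number from compound 3 to compound 4 (0.00 log units; within the scatter). Compound 4 is expected at 70000 nM, with an estimated range of 35000 nM to 100000 nM.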

Compound 4, half-maximal inhibitory concentration: 70700 nM
Beside the measured number, compound 4's estimate is 1.0-fold (0.00 log units) below it; the measured number falls inside the stated range.
By their numbers in this assay, from the lowest: compounds 1, 2, 3 and 4 (each within the scatter of the next).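

The para substituent on the six-membered aromatic ring of carbon only now spans fluoro, methyl and trifluoromethyl, and in this assay fluoro in place of methyl gives no change at the digits printed from compound 3 to compound 4 (within the scatter), while fluoro in place of trifluoromethyl gives no change at the digits printed from compound 1 to compound 4 (within the scatter). Exchanging the whole group, 4-fluorophenyl in place of 2-chloropyridin-3-yl, gives no change at the digits printed from compound 2 to compound 4 (within the scatter), so all four compounds print the same digits and none can be ranked above another in this assay. Nothing on hand speaks to what lies behind this flat result.

The compounds shown leave open whether any group at this position can separate from the shared value in this assay, since all of those shown are a small para substituent on a phenyl ring or a chloropyridinyl group. Going by these compounds, an amine, a carboxylic acid or a longer chain in that place could answer this, and how far the result depends on the shared core rather than on this group also remains open.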